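Swapping a chloropropyl chain for tert-butyl on a pyrimidinedione alkyne

The source may report more compounds than this note shows. Statements on the series, on what has been measured and on what is new or still open speak of the compounds shown alone.

Measured compounds:
compound 1, `CC(=O)OCC(CCn1cc(C#CCCCCl)c(=O)n(C(=O)c2ccccc2)c1=O)COC(C)=O`, 52800 nM
compound 2, `CC(=O)OCC(CCn1cc(C#CC(C)(C)C)c(=O)n(C(=O)c2ccccc2)c1=O)COC(C)=O`, 71500 nM
compound 3, `O=c1[nH]c(=O)n(CCC(CO)CO)cc1C#CCCCCl`, a limit only

All three were tested in a functional assay on HeLa cells (Homo sapiens) for antiproliferative activity, read by MTT assay, with a stated time of 72 h; a higher number here means a weaker inhibitor, a lower number a stronger inhibitor. Compound 1 and compound 2 share a core and differ by tert-butyl in place of 3-chloropropyl on a triple-bonded carbon; the step of a 1.4-fold higher number from compound 1 to compound 2 (0.13 log units; within the scatter) is small. Compound 3 has a different core; the difference between the two cores is not broken down here. In this assay compound 3 reached only the limit > 100000 nM, and the limit of > 100000 nM in this assay, at which 1 of the 3 values shown sits, is reached by one of the three measured values.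

The unmeasured compound 4, `CC(C)(C)C#Cc1cn(CCC(CO)CO)c(=O)[nH]c1=O`, relates to compound 3 as compound 2 does to compound 1: the change is tert-butyl in place of 3-chloropropyl on a triple-bonded carbon, the same change at the same place. Since the earlier step of a 1.4-fold higher number from compound 1 to compound 2 (0.13 log units; within the scatter) stayed within the scatter, the step that the limit leaves unreadable from compound 3 to compound 4 is expected to be of about that size, with compound 3 starting at a limit. Compound 4 is therefore expected to give 150000 nM, in a range from 70000 nM to 400000 nM, most likely again reported as a limit.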

Compound 4, half-maximal inhibitory concentration: > 100000 nM
Compound 4 was reported as a limit; the forecaster's own chance of this, stated with the estimate: 85%; the middle value lies beyond the limit too.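

In this assay, compound 3 and compound 4 are both reported only as a limit and not as a number, so the step between them cannot be read: the limit of > 100000 nM in this assay, at which 2 of the 4 values shown sit. The compounds shown leave open whether tert-butyl in place of 3-chloropropyl makes any difference on the core of compound 3.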